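Stability in rat liver microsomes, compounds 1 to 4

A few compounds are considered here, and "the series" means these few. Any claim that something is new, unique, unknown or untested is made for them only; others in the source may bear on it.

Measured compounds:
compound 1, `C[C@H](Nc1nc(N)nc(N)c1C#N)c1cc2ccc(F)cn2c(=O)c1-c1ccccc1`: 88%
compound 2, `C[C@H](Nc1nc(N)ncc1C#N)c1cc2ccc(F)cn2c(=O)c1-c1ccccc1`: 74%
compound 3, `C[C@H](Nc1ncnc(N)c1C#N)c1cc(=O)n2cc(F)ccc2c1-c1cc(F)cc(F)c1`: 60%

All numbers come from an ADME assay on microsomes from liver (Rattus norvegicus), read by LC-MS, using NADPH, with a stated time of 30 min, tested at 1 uM; on this read-out higher numbers stand for a more stable compound and lower numbers for a less stable compound. In this assay compound 1 gives 88% and compound 2 gives 74%; the change between them is amino in place of hydrogen on an aromatic carbon, and the step is a number 14 percentage points higher from compound 2 to compound 1 (beyond the scatter). Compound 3 gives 60%, the lowest of the three; the difference between its core and that of compound 2 is not broken down here. Compound 4, `C[C@H](Nc1nc(N)nc(N)c1C#N)c1cc(=O)n2cc(F)ccc2c1-c1cc(F)cc(F)c1`, is not yet measured. It differs from compound 3 by amino in place of hydrogen on an aromatic carbon, the same kind of change as from compound 2 to compound 1, although the entering group now sits between two ring nitrogen atoms and para to a cyano group rather than next to the ring nitrogen and ortho to a cyano group. For compound 4 a step of about a number 12 percentage points higher from compound 3 to compound 4 (beyond the scatter) is expected because the earlier step of a number 14 percentage points higher from compound 2 to compound 1 (beyond the scatter) followed the same kind of change. The estimate for compound 4 is 72%, with a range from 58% to 85%.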

Compound 4, percent of the compound remaining: 87%
Compound 4: the middle estimate sits 15 percentage points below what was measured, outside the stated range (above it).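

In this assay, amino in place of hydrogen on an aromatic carbon gives a number 27 percentage points higher from compound 3 to compound 4 (beyond the scatter). The change carries to the second core in the same direction, and the two steps do not differ in size: the same change on two cores in this assay, a number 14 percentage points higher (beyond the scatter) from compound 2 to compound 1 and a number 27 percentage points higher (beyond the scatter) from compound 3 to compound 4, 13 percentage points apart, within the scatter of two such steps. This rests on two pairs only, so it does not show that the step holds on further cores, and these pairs do not separate the effect of the core from that of where the amino group sits.

The compounds shown leave open whether a methyl group, a methylamino group or a chlorine atom on that aromatic carbon would give a similar step. They also leave open whether the amino step persists with other aryl groups on the core.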